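The source may hold more compounds than are shown below. What is called first, only, known or untested is meant among the compounds shown, and "the series" means these compounds.

Measured so far:
Compound 1 `COc1cc(-n2cnc3ccc(-c4ccc(C(F)(F)F)cc4)cc32)cc(OC)c1OC` gives 760 nM in a functional assay on MCF7 cells (Homo sapiens) for antiproliferative activity, read by MTT assay, with a stated time of 72 h; a higher number here means a weaker inhibitor, a lower number a stronger inhibitor.
Compound 2 `COc1cc(-n2cnc3ccc(-c4cccc(Cl)c4)cc32)cc(OC)c1OC` gives 3120 nM in this assay.

Going by the values given here, of these two numbers, compound 2 has the higher one, so it is the weaker inhibitor of the pair; the single measured step, a 4.1-fold higher number from compound 1 to compound 2 (0.61 log units; beyond the scatter), lies beyond the scatter. Compound 3 `COc1cc(-n2cnc3ccc(-c4ccc(Cl)cc4Cl)cc32)cc(OC)c1OC` differs from compound 2 in one place: 2,4-dichlorophenyl in place of 3-chlorophenyl on an aromatic carbon. Among the compounds with values here, the one measured step does not set a chlorophenyl against a dichlorophenyl, so it bears only loosely on this change; it shows that the group on this aromatic carbon can shift the number by a modest amount. With 2,4-dichlorophenyl entering for 3-chlorophenyl, a modest step toward a lower number is expected, though a step within the scatter cannot be ruled out. The step expected for compound 3 is a 2.1-fold lower number from compound 2 to compound 3 (0.32 log units; beyond the scatter). For compound 3 the estimated value is 1500 nM, with a range from 500 nM to 5000 nM.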

Compound 3, half-maximal inhibitory concentration: 5420 nM
Beside the measured number, compound 3's estimate is 3.6-fold (0.56 log units) below it; measured number outside the range, above it.
By their numbers in this assay, from the lowest: compound 1; then compounds 2 and 3 (each within the scatter of the next).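

Replacing 3-chlorophenyl with 2,4-dichlorophenyl on this aromatic carbon gives a 1.7-fold higher number from compound 2 to compound 3 (0.24 log units; within the scatter) in this assay, so the two chlorinated groups cannot be told apart here. Replacing 4-(trifluoromethyl)phenyl with 2,4-dichlorophenyl gives a 7.1-fold higher number from compound 1 to compound 3 (0.85 log units; beyond the scatter), which shows that compound 1 stands apart from both chlorinated compounds, not just from compound 2. No measurement is available to explain these numbers.

These three compounds cannot separate how many chlorines the phenyl ring carries from where they sit, and 4-chlorophenyl would help to test this. They also leave open how the number would respond to an unsubstituted phenyl, or to a phenyl ring bearing an amine or a carboxylic acid.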